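Methyl on the Amine Nitrogen of Compound 2

The source may hold more compounds than are shown below. What is called first, only, known or untested is meant among the compounds shown, and "the series" means these compounds.

Measured compounds:
compound 1 `CC[C@]1(c2ccsc2)OC[C@H]([C@@H]2CCCCN2)O1`: 124 nM
compound 2 `C[C@H](N)[C@H]1COC(c2ccccc2)(c2ccccc2)O1`: 607 nM

Both numbers come from a functional assay (brain) for displacement of a labelled ligand, with Rattus norvegicus as the target; on this read-out lower numbers stand for stronger inhibition and higher numbers for weaker inhibition. Compound 2 gives 607 nM in this assay, the higher of the two numbers. Among the compounds with values here, the only other number belongs to compound 1, which gives 124 nM; the gap between the two lies beyond the scatter, but the two structures differ in more than one place, so no single step connects them, and their two values say nothing more than that.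

Compound 3 `CN[C@@H](C)[C@H]1COC(c2ccccc2)(c2ccccc2)O1` differs from compound 2 in one place: methyl in place of hydrogen on an amine nitrogen. Within the data shown here, no pair of measured compounds shows the effect of this change, so the direction of the step rests on the change alone. A small step is expected in this assay, more likely toward a lower number than a higher one, but possibly not beyond the scatter. Compound 3 is therefore estimated at 350 nM, with a range from 100 nM to 1200 nM. The step that this estimate means, a 1.7-fold lower number from compound 2 to compound 3 (0.24 log units; within the scatter), is expected to be modest.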

Compound 3, inhibition constant: 703 nM
The estimate for compound 3 lay 2.0-fold (0.30 log units) below the measured number; measured number inside the range.
By their numbers in this assay, from the lowest: compound 1; then compounds 2 and 3 (each within the scatter of the next).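

Within the data shown here, this pair gives the first reading of a single change: in this assay, methyl in place of hydrogen on an amine nitrogen gives a 1.2-fold higher number from compound 2 to compound 3 (0.06 log units; within the scatter), a step within the scatter. The amine nitrogen of the 1-aminoethyl group, whose other neighbour is a saturated chain carbon, therefore carries one methyl with no difference that this read-out can resolve, and compound 2 and compound 3 cannot be told apart here. This finding rests on one pair with the shared core, so it gives no general rule for amino to methylamino changes and says nothing yet about the ring amine of compound 1. No measurement at hand accounts for this result.

On these data alone, whether an ethyl group, a longer chain or a second methyl on the same nitrogen would also leave the number within the scatter remains open, as does the outcome for an acetyl group, which would turn the amine into an amide. As far as these compounds go, it is equally open whether methyl on the ring nitrogen of compound 1 would give a similarly small step.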